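A few compounds are considered here, and "the series" means these few. Any claim that something is new, unique, unknown or untested is made for them only; others in the source may bear on it.

Of the compounds shown here, three from this series have been tested so far in an ADME assay on microsomes from liver (Mus musculus) for metabolic stability, read by LC-MS, with a stated time of 10 min; on this read-out higher numbers stand for a more stable compound and lower numbers for a less stable compound. Compound 1, with the structure `c1cnc2c(c1)CCC[C@@H]2N(CC1CC1)C[C@H]1Cc2c(cccc2N2CCNCC2)CN1`, gives 88.3% in this assay and stands highest of the three measured numbers. Compound 2, with the structure `CN(C[C@H]1Cc2c(cccc2N2CCNC(C)(C)C2)CN1)[C@H]1CCCc2cccnc21`, gives 44%, and compound 3, with the structure `CC(C)N1CCN(c2cccc3c2C[C@H](CN(C)[C@H]2CCCc4cccnc42)NC3)CC1`, gives 15.1%. Among the measured compounds shown here, the only one-place comparison among them runs from compound 2 to compound 3, where the change of 4-isopropylpiperazin-1-yl in place of 3,3-dimethylpiperazin-1-yl on an aromatic carbon brings a number 28.9 percentage points lower from compound 2 to compound 3 (beyond the scatter).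

Compound 4, with the structure `CC(C)N(C[C@H]1Cc2c(cccc2N2CCNCC2)CN1)[C@H]1CCCc2cccnc21`, has not yet been measured. It differs from compound 1 as follows: isopropyl in place of cyclopropylmethyl on an amine nitrogen. For the measured compounds named here, the one measured step concerns a different part of the shared core and does not bear directly on this change. Compound 1 and compound 2 also differ on the amine nitrogen, but they differ in a second place as well, so their two values alone cannot be read as a step for this swap. Going by the values given here, with no directly relevant step available, the expectation is a modest fall or none beyond the scatter, expressed as a number 13.3 percentage points lower from compound 1 to compound 4 (beyond the scatter). Compound 4 is therefore expected to give about 75% in this assay, in a range from 50% to 92%.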

Compound 4, percent of the compound remaining: 91%
Compound 4: the middle estimate sits 16 percentage points below what was measured; the measured number falls inside the stated range.
By their numbers in this assay, from the lowest: compound 3; then compound 2; then compounds 1 and 4 (each within the scatter of the next).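

On the amine nitrogen whose other neighbours are a saturated chain carbon and a saturated ring carbon, isopropyl in place of cyclopropylmethyl gives a number 2.7 percentage points higher from compound 1 to compound 4 (within the scatter) in this assay, so the two compounds cannot be told apart in this assay. Among the compounds shown here, this is the first clean one-place reading at this nitrogen, as the earlier step concerned a group on an aromatic carbon, and it shows that removing the three-membered ring and one carbon from this substituent leaves the read-out within the usual scatter. No measured information here explains this result.

From the compounds shown here alone, compound 2 carries a methyl group on this nitrogen but also differs in a second place, so its comparisons with compound 1 and compound 4 cannot be read as steps, and it remains open whether this nitrogen would accept a longer chain such as n-hexyl or a chain ending in a hydroxyl group as readily. Going by these compounds, it is also open whether the isopropyl for cyclopropylmethyl swap would read the same way with 3,3-dimethylpiperazin-1-yl or 4-isopropylpiperazin-1-yl on the aromatic carbon.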